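Urea aryl variation in the diaryl pyrazole series

This account rests on a few compounds, and the source may have more. Where it says the series, first, only, none or still open, it means among the compounds named here.

Three members of the series have numbers in a functional assay on UACC-62 cells (Homo sapiens) for inhibition, read by sulforhodamine B assay, with a stated time of 48 h, tested at 100 uM; a higher number here means a weaker effect of the compound at the concentration tested, a lower number a stronger effect. Compound 1 `COc1cc(Cl)cc(-c2nn(-c3cccc(NC(=O)Nc4ccc(Cl)c(C(F)(F)F)c4)c3)cc2-c2ccncc2)c1` gives -85%, compound 2 `COc1cc(Cl)cc(-c2nn(-c3cccc(NC(=O)Nc4cc(C(F)(F)F)cc(C(F)(F)F)c4)c3)cc2-c2ccncc2)c1` gives -71%, and compound 3 `COc1cc(Cl)cc(-c2nn(-c3cccc(NC(=O)Nc4ccc(Cl)c(Cl)c4)c3)cc2-c2ccncc2)c1` gives -32%. On these three numbers compound 3 stands highest, that is weakest: compound 2 lies a step beyond the scatter lower, and compound 1 lies further off still. Going by the values given here, the one step between members that differ in a single place is a number 53 percentage points higher from compound 1 to compound 3 (beyond the scatter), a large shift towards a weaker effect when chloro replaces trifluoromethyl on an aromatic carbon.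

Compound 4 `COc1cc(Cl)cc(-c2nn(-c3cccc(NC(=O)Nc4cccc(C(F)(F)F)c4)c3)cc2-c2ccncc2)c1` is the next member, not yet measured in this assay. Against compound 3 it reads: 3-(trifluoromethyl)phenyl in place of 3,4-dichlorophenyl on an amide-type nitrogen

The change thus brings a trifluoromethyl back onto the urea aryl while taking away both chlorines of the 3,4-dichlorophenyl. The step from compound 1 to compound 3 bears on it directly, since that step removed a trifluoromethyl and cost a large amount; compound 2, with its two trifluoromethyl groups, also sits well below compound 3. A move back downward, beyond the scatter, is therefore expected for compound 4, though perhaps not the full distance back to compound 1, because the step of a number 53 percentage points higher from compound 1 to compound 3 (beyond the scatter) also exchanged a chloro that compound 4 lacks. Compound 4 is estimated at -62% in this assay, within -85% to -32%, which means an expected step of a number 30 percentage points lower from compound 3 to compound 4 (beyond the scatter).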

Compound 4, a percentage reported as activity, at one concentration (the size of the read-out at that concentration, not a potency): -82%
Compound 4: middle estimate off by 20 percentage points, on the high side; measured number inside the range.
By their numbers in this assay, from the lowest: compounds 1 and 4 (each within the scatter of the next); then compound 2; then compound 3.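

In this assay, the single trifluoromethyl of the 3-(trifluoromethyl)phenyl group is enough for a strong effect: hydrogen in place of chloro gives a number 3 percentage points higher from compound 1 to compound 4 (within the scatter), so the chloro of compound 1 adds nothing that can be read. Hydrogen in place of the second trifluoromethyl gives a number 11 percentage points lower from compound 2 to compound 4 (beyond the scatter), a modest step, so among these aryl groups the bis(trifluoromethyl) pattern of compound 2 brings no stronger effect. The large step, a number 50 percentage points lower from compound 3 to compound 4 (beyond the scatter), shows that the weak number of compound 3 does not come from the loss of trifluoromethyl alone being offset by its two chlorines: the 3,4-dichlorophenyl group stands apart from all three trifluoromethyl-bearing aryl groups, and the chloro it shares with compound 1 is not what separates them.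

As far as these compounds go, how a nitrile or a methoxy on the urea aryl, or a plain phenyl, would compare with the 3-(trifluoromethyl)phenyl group remains open, as does whether the stronger and weaker effects seen at this one concentration would stand in the same order at other concentrations. The compounds shown come with no measurement that explains why trifluoromethyl and chloro differ so much on this aryl group.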